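Working notes: from compound 2 to compound 4

The compounds below may be only part of what the source reports. "The series", "measured", "known", "first", "only" and "open" are said of these compounds alone.

Measured in a functional assay on HepG2 cells (Homo sapiens) for cytotoxicity, read by MTT assay, with a stated time of 48 h; a lower number here means a stronger inhibitor, a higher number a weaker inhibitor:
- compound 1 `O=C1/C(=C\c2ccccc2)S/C(=N/c2ccccc2)N1Cc1ccncc1`: 25200 nM
- compound 2 `O=C1/C(=C\c2ccc(Cl)cc2)S/C(=N/c2ccccc2)N1Cc1ccncc1`: 28800 nM
- compound 3 `CC(C)c1ccc(/C=C2/S/C(=N/c3ccccc3)N(Cc3ccncc3)C2=O)cc1`: 32300 nM

Compound 2 lies within the scatter of both other compounds, so no order can be read among the three. Compound 4 `COc1cc(/C=C2/S/C(=N/c3ccccc3)N(Cc3ccncc3)C2=O)ccc1O` carries 4-hydroxy-3-methoxyphenyl in place of 4-chlorophenyl on a double-bonded chain carbon bound to a double-bonded ring carbon. Three measured changes to this aromatic group bear on it: a 1.1-fold higher number from compound 1 to compound 2 (0.06 log units; within the scatter), a 1.3-fold higher number from compound 1 to compound 3 (0.11 log units; within the scatter) and a 1.1-fold higher number from compound 2 to compound 3 (0.05 log units; within the scatter). All stay within the scatter, though none adds a hydroxy or methoxy group. No change beyond the scatter is therefore expected in this assay. The expected step is a 1.2-fold lower number from compound 2 to compound 4 (0.08 log units; within the scatter). Compound 4 is estimated at 24000 nM, with an expected range of 11000 nM to 50000 nM.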

Compound 4, half-maximal inhibitory concentration: 28600 nM
Beside the measured number, compound 4's estimate is 1.2-fold (0.08 log units) below it; low and high end bracket the measured number.
By their numbers in this assay, from the lowest: compounds 1, 4, 2 and 3 (each within the scatter of the next).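

In this assay, hydroxy and methoxy groups on this aromatic ring still give no change beyond the scatter, with (a 1.0-fold lower number from compound 2 to compound 4 (0.00 log units; within the scatter)) , (a 1.1-fold lower number from compound 3 to compound 4 (0.05 log units; within the scatter)) and (a 1.1-fold higher number from compound 1 to compound 4 (0.05 log units; within the scatter)) all within it. The position on the double-bonded chain carbon thus accepts a hydrogen-bond donor and acceptors, absent from 4-chlorophenyl, with no separation among the four compounds. No evidence is available to explain this. The compounds shown leave open whether an amine or a carboxylic acid on this ring, or a longer chain in its place, would move the number beyond the scatter.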